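This account rests on a few compounds, and the source may have more. Where it says the series, first, only, none or still open, it means among the compounds named here.

Measured in a functional assay on Caco-2 cells (Homo sapiens) for antiproliferative activity, read by MTT assay, with a stated time of 48 h; a higher number here means a weaker inhibitor, a lower number a stronger inhibitor:
- Compound 1 `C=CCN(C)C(=O)c1ccc(C(CC)(CC)c2ccc(OCCC(O)(CC)CC)c(C)c2)n1CC`: > 50000 nM (a limit)
- Compound 2 `CCn1c(C(=O)Nc2ccc(OC(F)(F)F)cc2)ccc1C(CC)(CC)c1ccc(OCCC(O)(CC)CC)c(C)c1`: > 50000 nM (a limit)
- Compound 3 `CCC(C)C(NC(=O)c1ccc(C(CC)(CC)c2ccc(OCCC(O)(CC)CC)c(C)c2)n1CC)C(=O)O`: 20000 nM

Within the data shown here, compound 3 holds the only actual number in the set. Compound 1 and compound 2 both give only (the limit of > 50000 nM in this assay, at which 2 of the 3 values shown sit).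

Compound 4 `CCC(C)C(CO)NC(=O)c1ccc(C(CC)(CC)c2ccc(OCCC(O)(CC)CC)c(C)c2)n1CC` has hydroxymethyl in place of carboxy on a saturated chain carbon bound to an amide-type nitrogen and a saturated chain carbon.

Among the measured compounds shown here, no measured step makes this exchange directly. The nearest evidence is an at least 2.5-fold lower number from compound 1 to compound 3 (0.39 log units; beyond the scatter), together with an at least 2.5-fold lower number from compound 2 to compound 3 (0.39 log units; beyond the scatter). Each of these rests on a limit at one end and replaces the whole group on the carbonyl carbon, so they bear on the change only indirectly. They show that compound 3 gives a number, but they do not separate the carboxy from the rest of the 1-carboxy-2-methylbutyl group.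

The expected shift in this assay is therefore small, within the scatter and leaning toward a higher number: a 1.5-fold higher number from compound 3 to compound 4 (0.18 log units; within the scatter). A reading that reaches only the limit also remains possible for compound 4.

In this assay the estimate for compound 4 is 30000 nM, with an expected range of 12000 nM to 50000 nM.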

Compound 4, half-maximal inhibitory concentration: > 50000 nM
Compound 4 gave a limit, no number; the forecaster's own chance of this, stated with the estimate: 35%; middle value at least 1.6-fold (0.22 log units) from the limit.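

In this assay, among these compounds, the change at this saturated chain carbon bound to an amide-type nitrogen gives the first step that isolates the carboxy (an at least 2.5-fold higher number from compound 3 to compound 4 (0.39 log units; beyond the scatter)). The earlier steps shown here replaced the whole group on the carbonyl carbon; this one shows that the measurable value of compound 3 depends on the carboxy itself and not only on the rest of the 1-carboxy-2-methylbutyl group. The steps to compound 4 from compound 1 and from compound 2 cannot be read, and compound 4 gives only a limit, so a number remains confined to compound 3: the limit of > 50000 nM in this assay, at which 3 of the 4 values shown sit.

The compounds shown leave open whether a group other than hydroxymethyl, such as a primary carboxamide, a methyl ester or a tetrazole, would keep a measurable value at this place. They also leave open whether the 2-methylbutyl part contributes, which a shorter chain on the same carbon could test.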